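The source may hold more compounds than are shown below. What is called first, only, known or untested is meant among the compounds shown, and "the series" means these compounds.

Working notes on a small set of thiophenyl-bearing analogues, all read in an assay on membranes from HeLa cells for displacement of a labelled ligand from adenosine receptor A3 (Homo sapiens), read by scintillation counting, with a stated time of 180 min, tested at 1 uM; a lower number here means less inhibition, a higher number more inhibition at the concentration tested (going by the name of the read-out).

Compound 1 `COC(=O)C1=C(C)NC(=S)NC1c1cccs1` gives 1% in this assay. Compound 2 `CCCOC(=O)C1=C(C)NC(=S)NC1c1cccs1` carries the change ethyl in place of hydrogen on a saturated chain carbon bound to an oxygen next to a carbonyl group and in this assay compound 2 gives 10%, the step being a number 9 percentage points higher from compound 1 to compound 2 (within the scatter). Compound 3 `COC(=O)C1=C(C)NC(=S)NC1c1ccsc1` differs from compound 1 by thiophen-3-yl in place of thiophen-2-yl on a saturated ring carbon and in this assay compound 3 gives 3%, the step being a number 2 percentage points higher from compound 1 to compound 3 (within the scatter). All three numbers lie within the scatter of one another, so no ranking among compound 1, compound 2 and compound 3 is drawn; all three sit at the low end of the read-out.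

Compound 4 `CCCOC(=O)C1=C(C)NC(=S)NC1c1ccsc1` is not yet measured. It differs from compound 3 by ethyl in place of hydrogen on a saturated chain carbon bound to an oxygen next to a carbonyl group. Among the compounds with values here, this is the same change, at a place described in the same words, as the one separating compound 1 from compound 2; it occurs twice in the set. The two cores differ in the way set out above for compound 3 against compound 1.

In this assay, within the data shown here, the step expected from compound 3 to compound 4 is a number 7 percentage points higher from compound 3 to compound 4 (within the scatter), set beside the earlier one of a number 9 percentage points higher from compound 1 to compound 2 (within the scatter); this expectation rests on the single precedent, because compound 2 showed 10% against compound 1, and on nothing further, since only one pair carries the change. The uncertainty is wide, as one precedent within the scatter does not fix a direction.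

Compound 4 is expected to give 10% in this assay, with an estimated range from 0% to 25%.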

Compound 4, a percentage reported as inhibition, at one concentration (the size of the read-out at that concentration, not a potency): 1%
Estimate against measurement, compound 4: 9 percentage points above; the range from low to high includes it.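

In this assay the change from methoxycarbonyl to propoxycarbonyl on the core of compound 3 gives a number 2 percentage points lower from compound 3 to compound 4 (within the scatter), and set beside its counterpart on the core of compound 1 it shows no difference beyond the scatter: the same change on two cores in this assay, a number 9 percentage points higher (within the scatter) from compound 1 to compound 2 and a number 2 percentage points lower (within the scatter) from compound 3 to compound 4, 11 percentage points apart, within the scatter of two such steps.
Thiophen-3-yl in place of thiophen-2-yl on the propoxycarbonyl core gives a number 9 percentage points lower from compound 2 to compound 4 (within the scatter), and this step likewise stays within the scatter of its counterpart: the same change on two cores in this assay, a number 2 percentage points higher (within the scatter) from compound 1 to compound 3 and a number 9 percentage points lower (within the scatter) from compound 2 to compound 4, 11 percentage points apart, within the scatter of two such steps.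
Neither change therefore shows a dependence on the core in this series, but this does not establish that either step transfers from one core to another, since every step here lies within the scatter, no direction is fixed for either change, and all four compounds sit at the low end of a read-out taken at one concentration.

The compounds shown leave open whether a longer chain than propyl, or a carboxylic acid or an amide in place of methoxycarbonyl, would move the read-out clear of the scatter. They also leave open whether either change would show a consistent step on a compound giving a higher number in this assay, as none of these four offers such a starting point.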